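Carboxyphenoxy in Place of Carboxyphenyl on a Bile Acid Receptor Core

This account rests on a few compounds, and the source may have more. Where it says the series, first, only, none or still open, it means among the compounds named here.

Compound 1 `Cc1ccccc1-n1nc(C)c2c1NC(=O)[C@H](C)S[C@@H]2c1ccc(-c2cccc(C(=O)O)c2)cc1`: "not active" (no number reported)
Compound 2 `Cc1ccccc1-n1nc(C)c2c1NC(=O)[C@H](C)S[C@@H]2c1ccc(-c2ccoc2)cc1`: 3500 nM
Compound 3 `Cc1nn(-c2ccccc2I)c2c1C(c1ccc(Oc3ccccc3)cc1)SC(C)C(=O)N2`: 1300 nM

Three compounds sharing the core of compound 1 have been examined in an assay on isolated protein for agonist activity at Bile acid receptor (Homo sapiens), read by AlphaScreen, with a stated time of 30 min; a higher number here means that more compound is needed for the effect, a lower number that less compound is needed. Compound 1 was reported as "not active" (no number reported), so no number places it among the others. Compound 2 gives 3500 nM in this assay, and compound 3, which carries a phenoxy group instead, gives 1300 nM. Compound 4 `Cc1ccccc1-n1nc(C)c2c1NC(=O)[C@H](C)S[C@@H]2c1ccc(Oc2ccc(C(=O)O)cc2)cc1` has not yet been measured. It differs from compound 1 in one place: 4-carboxyphenoxy in place of 3-carboxyphenyl on an aromatic carbon. Going by the values given here, no measured pair shows this exact change, so the size of the step cannot be taken from the data. Compound 1 gave no number at all, while the two compounds with a number, compound 2 and compound 3, sit in the low micromolar range. Compound 4 is therefore expected to show either a value in that range or again no number. Its half-maximal effective concentration in this assay is estimated at 5000 nM, with a plausible range from 1500 nM to 20000 nM.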

Compound 4, half-maximal effective concentration: "not active" (no number reported)
For compound 4 the study gives words and no number, so the estimate cannot be set against anything.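

Going by these compounds alone, compound 1 and compound 4 both came back without a number, so no step between them can be read. The compounds shown leave open how far 3-carboxyphenyl and 4-carboxyphenoxy differ in their effect on the shared core. Nothing available offers an explanation for this result.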